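Swapping the pendant aryl ring for a methyl analogue

The source may hold more compounds than are shown below. What is called first, only, known or untested is meant among the compounds shown, and "the series" means these compounds.

Three compounds with a shared core were tested in a functional assay on NCI-H460 cells (Homo sapiens) for antiproliferative activity, read by MTT assay, with a stated time of 48 h; on this read-out lower numbers stand for stronger inhibition and higher numbers for weaker inhibition:

Compound 1, `COc1ccc(-c2nc3cccc(-c4cc(OC)c(OC)c(OC)c4)c3o2)cc1OC`, gives > 25000 nM, which is a limit of the assay rather than a number.
Compound 2, `COc1cc(-c2cccc3nc(-c4cccc(F)c4)oc23)cc(OC)c1OC`, gives 3300 nM.
Compound 3, `COc1cc(-c2cccc3nc(-c4ccc(Br)cc4)oc23)cc(OC)c1OC`, gives > 25000 nM, again a limit of the assay and not a number.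

Compound 1 therefore stands at the limit, where two of the three values sit (the limit of > 25000 nM in this assay, at which 2 of the 3 values shown sit); only compound 2 shows a measurable number. The unmeasured compound 4, `COc1cc(-c2cccc3nc(-c4ccc(C)cc4)oc23)cc(OC)c1OC`, differs from compound 1 in one place: 4-methylphenyl in place of 3,4-dimethoxyphenyl on an aromatic carbon. For the measured compounds named here, two measured steps bear on this change. Replacing the same group with 3-fluorophenyl gives an at least 7.5-fold lower number from compound 1 to compound 2 (0.87 log units; beyond the scatter), whereas the step to 4-bromophenyl is a step that the two limits leave unreadable from compound 1 to compound 3, and between those two aryl groups the step is an at least 7.5-fold higher number from compound 2 to compound 3 (0.87 log units; beyond the scatter). The 4-methylphenyl group in compound 4 resembles 4-bromophenyl in carrying a single substituent, and compound 3 stays at the limit, so a return to the limit is the more likely outcome, with a measurable number possible but not expected. Compound 4 is expected to give 20000 nM, within 5000 nM to 60000 nM. That expectation means an at least 1.2-fold lower number from compound 1 to compound 4 (0.09 log units; that floor lies within the scatter), which is expected to stay within the scatter.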

Compound 4, half-maximal inhibitory concentration: 1900 nM
Estimate against measurement, compound 4: 11-fold (1.02 log units) above; the measured number lies below the stated range.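

In this assay, putting methyl in place of bromo gives an at least 13-fold lower number from compound 3 to compound 4 (1.11 log units; beyond the scatter), so a single substituent on this phenyl ring does not by itself leave a compound at the limit; what sits on the ring matters, and even this one small exchange separates a measurable compound from one that is not. Changing the whole pendant ring from 3,4-dimethoxyphenyl to 4-methylphenyl gives an at least 13-fold lower number from compound 1 to compound 4 (1.11 log units; beyond the scatter), which makes 4-methylphenyl the second group shown, after 3-fluorophenyl, to bring a number out of the limit at this carbon of the five-membered ring. The two groups cannot be told apart in this assay, as the comparison gives a 1.7-fold lower number from compound 2 to compound 4 (0.24 log units; within the scatter).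

How far these readings go is restricted, as only two compounds carry real numbers and the others give only a limit: the limit of > 25000 nM in this assay, at which 2 of the 4 values shown sit.
The compounds shown leave open whether a chloro group, an amine or a carboxylic acid on the pendant ring would give a measurable number or a limit, and whether the lone methoxy group of a 4-methoxyphenyl ring would behave like methyl or like the pair in compound 1.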